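The source may report more compounds than this note shows. Statements on the series, on what has been measured and on what is new or still open speak of the compounds shown alone.

Measured so far in a functional assay on A549 cells (Homo sapiens) for antiproliferative activity, read by MTT assay, with a stated time of 72 h; a lower number here means a stronger inhibitor, a higher number a weaker inhibitor:
compound 1, `COc1cc2ncnc(Nc3cccc(Cl)c3)c2cc1OCCCCC(=O)Nc1ccc(S(N)(=O)=O)cc1`, gives 11200 nM.
compound 2, `COc1cc2ncnc(Nc3cccc(F)c3)c2cc1OCCCCC(=O)Nc1ccc(S(N)(=O)=O)cc1`, reaches only the limit of the assay, > 40000 nM.
compound 3, `COc1cc2ncnc(Nc3ccc(F)cc3)c2cc1OCCCCC(=O)Nc1ccc(S(N)(=O)=O)cc1`, likewise reaches only the limit, > 40000 nM.

For the measured compounds named here, compound 3 thus stands at the limit, sharing it with compound 2 (the limit of > 40000 nM in this assay, at which 2 of the 3 values shown sit), while compound 1 is the only one read as a number. Compound 4, `COc1ccc(Nc2ncnc3cc(OC)c(OCCCCC(=O)Nc4ccc(S(N)(=O)=O)cc4)cc23)cc1OC`, differs from compound 3 by 3,4-dimethoxyphenyl in place of 4-fluorophenyl on a nitrogen on an aromatic ring. The measured steps only alter a halogen or its position on that ring: an at least 3.5-fold higher number from compound 1 to compound 2 (0.55 log units; beyond the scatter) and an at least 3.5-fold higher number from compound 1 to compound 3 (0.55 log units; beyond the scatter), both toward weaker inhibition, while a step that the two limits leave unreadable from compound 2 to compound 3. Going by the values given here, no measured step replaces a halogen with methoxy groups, so the direction of this change cannot be read from them. The expected step is accordingly a step that the limit leaves unreadable from compound 3 to compound 4. Compound 4 is estimated at 45000 nM, with a range from 12000 nM to 120000 nM.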

Compound 4, half-maximal inhibitory concentration: > 40000 nM
Compound 4: no number, only a limit (the forecaster's own chance of this, stated with the estimate: 70%); the middle value does not contradict the limit.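

In this assay, compound 4 gives > 40000 nM, which is a limit of the assay and not a number. Methoxy groups on this ring, like the fluoro compounds before them, therefore give no measurable value, and 3,4-dimethoxyphenyl in place of 3-chlorophenyl gives an at least 3.5-fold higher number from compound 1 to compound 4 (0.55 log units; beyond the scatter). The steps to compound 4 from compound 2 and compound 3 cannot be read, and compound 1 remains the only compound with a number: the limit of > 40000 nM in this assay, at which 3 of the 4 values shown sit.

As far as these compounds go, how compound 2, compound 3 and compound 4 rank against one another stays open. So does whether a bromophenyl group on that nitrogen would match or pass compound 1.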